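The source may report more compounds than this note shows. Statements on the series, on what has been measured and on what is new or still open speak of the compounds shown alone.

Measured so far in a functional assay on HCT-116 cells (Homo sapiens) for cytotoxicity, read by MTT assay, with a stated time of 72 h; a lower number here means a stronger inhibitor, a higher number a weaker inhibitor: compound 1 `[N-]=[N+]=NCc1nnc(-c2cc(S(N)(=O)=O)c(SCc3ccccc3)cc2Cl)o1` gives 100000 nM; compound 2 `CC(C)(O)c1cn(Cc2nnc(-c3cc(S(N)(=O)=O)c(SCc4ccccc4)cc3Cl)o2)nn1` gives 82000 nM; compound 3 `NCc1nnc(-c2cc(S(N)(=O)=O)c(SCc3ccccc3)cc2Cl)o1` gives 120000 nM.

Compound 3 stands highest of the three numbers, but its steps to the others are small: a 1.2-fold higher number from compound 1 to compound 3 (0.08 log units; within the scatter) and a 1.5-fold higher number from compound 2 to compound 3 (0.17 log units; within the scatter), so the three compounds are not separated beyond the scatter. Compound 4 `NS(=O)(=O)c1cc(-c2nnc(/C=C/c3ccccc3)o2)c(Cl)cc1SCc1ccccc1` differs from compound 3 by 2-phenylethenyl in place of aminomethyl on an aromatic carbon. Within the data shown here, no measured step alters this part of the shared core in the same way; the measured steps of a 1.2-fold lower number from compound 1 to compound 2 (0.09 log units; within the scatter) and a 1.2-fold higher number from compound 1 to compound 3 (0.08 log units; within the scatter) only show that varying the group on the saturated chain carbon left the numbers within the scatter. Compound 4 is therefore expected to stay near compound 3, with an estimated step of a 1.2-fold lower number from compound 3 to compound 4 (0.08 log units; within the scatter) in this assay. Compound 4 is estimated at 100000 nM, within a range of 30000 nM to 300000 nM.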

Compound 4, half-maximal inhibitory concentration: 18000 nM
For compound 4 the middle estimate is 5.6-fold (0.74 log units) above the measured one; the measured number lies below the stated range.
By their numbers in this assay, from the lowest: compound 4; then compounds 2, 1 and 3 (each within the scatter of the next).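

Among these compounds, in (this assay) the change at this aromatic carbon of the five-membered ring separates compounds beyond the scatter for the first time: 2-phenylethenyl gives a modest shift against aminomethyl (a 6.7-fold lower number from compound 3 to compound 4 (0.82 log units; beyond the scatter)), against the triazole-bearing methyl group (a 4.6-fold lower number from compound 2 to compound 4 (0.66 log units; beyond the scatter)) and against azidomethyl (a 5.6-fold lower number from compound 1 to compound 4 (0.74 log units; beyond the scatter)). Replacing the whole group thus moved the number, where varying the group on the saturated chain carbon had not. Nothing available bears on the reason for this shift. The compounds shown leave open whether the double bond or the aromatic ring of 2-phenylethenyl goes with the lower number, and how a saturated 2-phenylethyl chain or a plain phenyl would compare here.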